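The source may report more compounds than this note shows. Statements on the series, on what has been measured and on what is new or still open speak of the compounds shown alone.

Among the compounds with values here, compound 2 `Cc1cccc(N2C(=O)CSC2c2cccc(C(=O)NCCCCc3ccccc3)c2)c1` stands highest of the two numbers measured so far: in a functional assay on HOS cells (Homo sapiens) for inhibition, read by CCK-8 assay, with a stated time of 72 h, tested at 1 uM (on this read-out lower numbers stand for less inhibition and higher numbers for more inhibition at the one concentration tested (going by the name of the read-out)), compound 2 gives 84%. Within the data shown here, its nearest neighbour is compound 1 `O=C(NCCCCc1ccccc1)c1cccc(C2SCC(=O)N2c2ccccc2)c1`, which in this assay gives 55%, and the single measured step is a number 29 percentage points higher from compound 1 to compound 2 (beyond the scatter). Compound 3 `CCN1C(=O)CSC1c1cccc(C(=O)NCCCCc2ccccc2)c1` has not yet been tested in this assay. It differs from compound 2 in one place: ethyl in place of 3-methylphenyl on an amide-type nitrogen in a ring. Among the measured compounds shown here, the only measured step bears on this change indirectly, since it shows that the methyl on the aromatic ring raised inhibition, and in compound 3 that methyl leaves together with the whole ring. A drop in this assay is therefore expected for compound 3, roughly undoing the gain from compound 1 to compound 2, that is a number 39 percentage points lower from compound 2 to compound 3 (beyond the scatter). The estimate for compound 3 in this assay is 45%, with a range from 15% to 75%.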

Compound 3, a percentage reported as inhibition, at one concentration (the size of the read-out at that concentration, not a potency): 6%
Compound 3: the middle estimate sits 39 percentage points above what was measured, outside the stated range (below it).
By their numbers in this assay, from the lowest: compound 3; then compound 1; then compound 2.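

Replacing the aromatic ring on the amide-type nitrogen in the ring with ethyl gives a number 78 percentage points lower from compound 2 to compound 3 (beyond the scatter) in this assay, a far larger change than the gain seen when the methyl was added to the phenyl ring. The same swap starting from the plain phenyl gives a number 49 percentage points lower from compound 1 to compound 3 (beyond the scatter), so among these three compounds inhibition is much higher with either aromatic group than with ethyl, and the methyl alone does not account for the difference. Nothing available explains why this change costs so much.

The three compounds leave open whether a non-aromatic ring such as cyclohexyl, or a longer chain such as n-butyl, would restore inhibition at this position, or whether an aromatic ring is needed. Going by these compounds, it also remains open how a methoxy group or a chlorine on the phenyl ring would compare with the methyl.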